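Paw edema series: compound 1 to compound 4

A few compounds are considered here, and "the series" means these few. Any claim that something is new, unique, unknown or untested is made for them only; others in the source may bear on it.

Measured so far:
compound 1 `Clc1ccc2nc(Nc3nnc(-c4ccccc4Cl)o3)sc2c1` — 53%
compound 2 `Cc1ccccc1-c1nnc(Nc2nc3ccc(Cl)cc3s2)o1` — 23.9%
compound 3 `CC.O=[N+]([O-])c1ccc(-c2nnc(Nc3nc4ccc(Cl)cc4s3)o2)cc1` — 19.2%

In a functional assay on the whole organism (strain Wistar) for inhibition, with Rattus norvegicus as the target, read by paw edema, with stated times of 1 h and 3 h, at a dose of 70 mg/kg by the oral route (on this read-out higher numbers stand for more inhibition at the one dose given (going by the name of the read-out) and lower numbers for less inhibition), compound 1 gives 53%, the highest of the three numbers. The nearest is compound 2 at 23.9%; the furthest is compound 3 at 19.2%. Both gaps are beyond the scatter, so compound 1 stands clearly above the other two.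

Among the compounds with values here, the one step that can be counted runs from compound 1 to compound 2: a number 29.1 percentage points lower from compound 1 to compound 2 (beyond the scatter). Compound 3 shares no single-point difference with compound 1, so its value only shows that a differently substituted phenyl at the same ring position also sits well below compound 1.

Compound 4 `Sc1nnc(Nc2nc3ccc(Cl)cc3s2)o1` differs from compound 1 as follows: sulfanyl in place of 2-chlorophenyl on an aromatic carbon. Within the data shown here, no measured step covers the removal of the whole aryl group in favour of sulfanyl, so the expectation rests on the general picture: every variation of the aryl group seen so far has lowered inhibition in this assay, and a much larger change to that position is not expected to restore it. A loss in this assay is therefore expected, a number 31 percentage points lower from compound 1 to compound 4 (beyond the scatter), of a size comparable to or larger than the measured step from compound 1 to compound 2, though with wide uncertainty.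

Compound 4 is estimated at 22% in this assay, with a range from 8% to 42%.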

Compound 4, a percentage reported as inhibition, in the whole organism at one dose (the size of the read-out at that dose, not a potency): 61.7%
The estimate for compound 4 lay 39.7 percentage points below the measured number, outside the stated range (above it).
By their numbers in this assay, from the lowest: compounds 3 and 2 (each within the scatter of the next); then compounds 1 and 4 (each within the scatter of the next).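

Replacing 2-chlorophenyl with sulfanyl on this aromatic carbon of the five-membered aromatic ring gives a number 8.7 percentage points higher from compound 1 to compound 4 (within the scatter), so in this assay the six-membered aromatic ring can leave this position without a change beyond the scatter. Set against the 2-methylphenyl group, the same replacement gives a number 37.8 percentage points higher from compound 2 to compound 4 (beyond the scatter), which shows that the low number of compound 2 does not mark a general loss on moving away from 2-chlorophenyl; an aryl group at this position is not needed to reach the level of compound 1. No measured information on the compounds shown accounts for either step.

On these data alone, it remains open whether the number of compound 4 is specific to sulfanyl or would hold for other small groups on the same carbon, such as an amine, a hydroxyl or a methylthio group, the last of which would also show whether the hydrogen of sulfanyl matters. As far as these compounds go, it also remains open how an unsubstituted phenyl group would compare with 2-chlorophenyl and 2-methylphenyl, and whether a longer chain on the sulfur would keep the inhibition.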